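The source may report more compounds than this note shows. Statements on the series, on what has been measured and on what is new or still open speak of the compounds shown alone.

In an assay on isolated protein for inhibition of protoporphyrinogen oxidase (Homo sapiens), read by capillary electrophoresis (a higher number here means a weaker inhibitor, a lower number a stronger inhibitor), compound 2 `CCOC(=O)CSc1nc2cc(-n3nc(C(C)(C)C)sc3=O)c(Br)cc2s1` gives 15600 nM, the higher of the two numbers measured. Its nearest neighbour, compound 1 `CCOC(=O)CSc1nc2cc(-n3nc(C(C)(C)C)sc3=O)c(Cl)cc2s1`, gives 5820 nM in this assay, and the step from it, a 2.7-fold higher number from compound 1 to compound 2 (0.43 log units; beyond the scatter), concerns a bromo in place of a chloro. Compound 3 `CCOC(=O)CCCSc1nc2cc(-n3nc(C(C)(C)C)sc3=O)c(Br)cc2s1` differs from compound 2 by 2-(ethoxycarbonyl)ethyl in place of ethoxycarbonyl on a saturated chain carbon bound to a sulfur. For the measured compounds named here, no measured step touches this chain, since the only step available concerns a halogen on the aromatic ring, so no change beyond the scatter is predicted. For compound 3 the estimate is 15600 nM, with a range from 5000 nM to 50000 nM. The expected step is therefore no change at the digits printed from compound 2 to compound 3 (within the scatter).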

Compound 3, inhibition constant: 245000 nM
Compound 3: the middle estimate sits 16-fold (1.20 log units) below what was measured; the measured number lies above the stated range.
By their numbers in this assay, from the lowest: compound 1; then compound 2; then compound 3.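

Lengthening the chain on the sulfur has a clear cost: 2-(ethoxycarbonyl)ethyl in place of ethoxycarbonyl on this saturated chain carbon gives a 16-fold higher number from compound 2 to compound 3 (1.20 log units; beyond the scatter) in this assay. The earlier halogen step said nothing about this chain, and this result shows that the number is sensitive to its length, with the longer chain giving the weaker inhibitor of this pair. Nothing measured explains this loss.

From the compounds shown here alone, it remains open how a carboxylic acid or an amide in place of the ethyl ester would read on either chain. Going by these compounds, the effect of the longer chain with chloro in place of bromo also remains open.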